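This account rests on a few compounds, and the source may have more. Where it says the series, first, only, none or still open, it means among the compounds named here.

Compound 3 `Cc1ccccc1C(=O)c1ccc2c(c1)C(n1ccccc1=O)=CC(C)(C)O2` stands highest of the three numbers in a functional assay (aorta) with Rattus norvegicus as the target (a lower number here means a less potent compound, a higher number a more potent compound, by a factor of ten per unit of this negative logarithm), at 6.83; compound 2 `COc1ccc2c(c1)C(n1ccccc1=O)=CC(C)(C)O2` sits nearest, at 6.55, and compound 1 `CC1(C)C=C(n2ccccc2=O)c2ccccc2O1` furthest, at 5.43. Compound 4 `CC1(C)C=C(n2ccccc2=O)c2cc(C(=N)NO)ccc2O1` differs from compound 3 by a group of 4 heavy atoms (1 carbon, 2 nitrogen, 1 oxygen; no ring) in place of a group of 9 heavy atoms (8 carbon, 1 oxygen; one six-membered aromatic ring of carbon only), on an aromatic carbon. For the measured compounds named here, two measured steps bear on substitution at that carbon: a number 1.40 log units higher from compound 1 to compound 3 (beyond the scatter) and a number 0.28 log units higher from compound 2 to compound 3 (within the scatter). Both show that a group at this position gives a higher number than hydrogen does, while exchanging one group for another moved the number little. The entering group resembles neither measured substituent, so the expectation rests mainly on how little compound 3 departs from compound 2. Compound 4 is therefore expected to give 6.4, between 5.6 and 7.2. The step of a number 0.43 log units lower from compound 3 to compound 4 (beyond the scatter) that this estimate means is expected to stay within the scatter.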

Compound 4, logarithm of the reciprocal of the active concentration, log(1/C): 5.99
The estimate for compound 4 lay 0.41 log units above the measured number, and the stated range covers the measured number.
By their numbers in this assay, from the lowest: compound 1; then compound 4; then compounds 2 and 3 (each within the scatter of the next).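

Hydrogen is not the only group that the entering group surpasses on this aromatic carbon in this assay: the exchange gives a number 0.56 log units higher from compound 1 to compound 4 (beyond the scatter) and so adds a third substituent that stands above hydrogen. The choice of group nevertheless matters here, with a number 0.56 log units lower from compound 2 to compound 4 (beyond the scatter) and a number 0.84 log units lower from compound 3 to compound 4 (beyond the scatter) in a series where methoxy and (2-methylphenyl)carbonyl had stayed within the scatter of each other. No available measurement bears on the reason for this difference. As far as these compounds go, whether an amine or a carboxylic acid on this carbon would give a number nearer that of compound 4 or that of compound 3 remains open.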